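A few compounds are considered here, and "the series" means these few. Any claim that something is new, unique, unknown or untested is made for them only; others in the source may bear on it.

Of the compounds shown here, two of the same core have been measured so far. Compound 1, `Nc1ccc(S(=O)(=O)Nc2ccnc3cc(C(F)(F)F)ccc23)cc1`, carries a simple amine on the sulfonyl-bearing ring, and in a functional assay on HepG2 cells (Homo sapiens) for antiproliferative activity, read by sulforhodamine B assay, with a stated time of 48 h (a lower number here means a stronger inhibitor, a higher number a weaker inhibitor), compound 1 gives 93100 nM. Compound 2, `N=C(N)NS(=O)(=O)c1ccc(N/C(S)=N\c2ccnc3cc(C(F)(F)F)ccc23)cc1`, links the two ring systems through a thiourea and ends in a sulfonylguanidine; in this assay compound 2 gives 33500 nM, the lowest of the two numbers, with compound 1 a step beyond the scatter above it.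

Compound 3, `O=S(=O)(Nc1nccs1)c1ccc(N/C(S)=N\c2ccnc3cc(C(F)(F)F)ccc23)cc1`, keeps the thiourea link of compound 2 and alters only the end of the sulfonamide: a group of 5 heavy atoms (3 carbon, 1 nitrogen, 1 sulfur; one five-membered aromatic ring with 2 hetero atoms) in place of a group of 3 heavy atoms (1 carbon, 2 nitrogen; no ring), on a sulfonamide nitrogen. Among the measured compounds shown here, no measured pair here changes this position alone, so there is no comparable step to lean on; the thiourea part shared with compound 2 is unchanged. The swap from compound 2 to compound 3 is therefore expected to give a modest shift, a 1.3-fold lower number from compound 2 to compound 3 (0.13 log units; within the scatter), not clearly beyond the scatter in either direction. For compound 3 the estimated value in this assay is 25000 nM, with a plausible range from 8000 nM to 80000 nM.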

Compound 3, half-maximal inhibitory concentration: 28200 nM
Beside the measured number, compound 3's estimate is 1.1-fold (0.05 log units) below it; low and high end bracket the measured number.
By their numbers in this assay, from the lowest: compounds 3 and 2 (each within the scatter of the next); then compound 1.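

Among the compounds shown here, with the thiourea link and the rest of the molecule unchanged, placing a 1,3-thiazol-2-yl group on the sulfonamide nitrogen gives a 1.2-fold lower number from compound 2 to compound 3 (0.07 log units; within the scatter) in this assay and so provides the first direct comparison at this position. The two groups differ clearly in what is counted: one is a five-membered aromatic ring with 2 hetero atoms and 0 hydrogen-bond donors, the other has no ring and has 2 hydrogen-bond donors, yet this read-out does not tell them apart. No measurement shown here bears on why the two groups read alike.

As far as these compounds go, with only these two groups compared, it remains open whether any group on this nitrogen can shift the number beyond the scatter, for example a small methyl group, an acetyl group or a six-membered pyridin-2-yl ring. From the compounds shown here alone, the part played by the thiourea link also remains open, since compound 1 differs from compound 2 in more than one place, and a comparison with a urea link or a plain amide link, keeping the end group fixed, would be needed to read it alone.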